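Amide nitrogen substituents and cytotoxicity in a phenylcyclopentane series

This account rests on a few compounds, and the source may have more. Where it says the series, first, only, none or still open, it means among the compounds named here.

Measured compounds in an ADME assay on MDCK cells (Canis lupus familiaris) for cytotoxicity; on this read-out higher numbers stand for lower toxicity in this test and lower numbers for higher toxicity in this test:
- compound 1 `O=C(N1CCCc2ccccc21)C1(c2ccccc2)CCCC1`: 24000 nM
- compound 2 `O=C(Nc1ccccc1)C1(c2ccccc2)CCCC1`: a limit of the assay, > 100000 nM
- compound 3 `CN(C(=O)C1(c2ccccc2)CCCC1)c1ccccc1`: 52000 nM

Compound 3 stands highest of the two numbers shown in this assay; compound 1 lies a step below it, and compound 2 sits at a limit of the assay rather than a number, as the limit of > 100000 nM in this assay, at which 1 of the 3 values shown sits, records. Within the data shown here, the one measured step that touches the amide nitrogen is an at least 1.9-fold lower number from compound 2 to compound 3 (0.28 log units; that floor lies within the scatter), which is small and runs only from a limit, so it says little about the size of change this position can produce.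

Compound 4 `CN(C(=O)C1(c2ccccc2)CCCC1)C1CCCCC1` is not yet measured. It differs from compound 3 in one place: cyclohexyl in place of phenyl on an amide-type nitrogen. Among the measured compounds shown here, no measured step swaps an aromatic ring for a saturated one on this nitrogen, and compound 1 and compound 3 differ in more than one place, so only their two values can be set side by side. The step from compound 3 to compound 4 is therefore expected to stay within the scatter, a 1.3-fold lower number from compound 3 to compound 4 (0.11 log units; within the scatter). In this assay compound 4 is estimated at 40000 nM, with a range from 14000 nM to 110000 nM.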

Compound 4, half-maximal cytotoxic concentration: 21000 nM
The estimate for compound 4 lay 1.9-fold (0.28 log units) above the measured number; the measured number falls inside the stated range.
By their numbers in this assay, from the lowest: compounds 4 and 1 (each within the scatter of the next); then compound 3. At a limit, above all of these: compound 2.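

In this assay, among these compounds, the change from phenyl to cyclohexyl on the amide-type nitrogen gives a 2.5-fold lower number from compound 3 to compound 4 (0.39 log units; beyond the scatter) and so provides the first step at this position that has a number at both ends and lies beyond the scatter, whereas the earlier step, an at least 1.9-fold lower number from compound 2 to compound 3 (0.28 log units; that floor lies within the scatter), starts from a limit of the assay and has a floor within the scatter. Phenyl and cyclohexyl match in the computed counts of heavy atoms, donors and acceptors, and neither carries a net charge, so this pair separates an aromatic ring from a non-aromatic ring on this nitrogen with those counts held equal, and the read-out moves modestly towards higher toxicity in this test. Nothing at hand gives a cause for this step.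

Still open, from the compounds shown here alone, is whether a hydroxyl or an amine on the cyclohexyl ring, or a longer chain in place of the methyl on the nitrogen, would move the number further. Also open, going by these compounds, is whether the same ring change gives a step of similar size on a nitrogen that keeps the amide hydrogen.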